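Swapping a Dodecyl Chain for a Cyanophenyl Group

The source may hold more compounds than are shown below. What is called first, only, known or untested is meant among the compounds shown, and "the series" means these compounds.

Compound 1 `CCCCCCCCCCCCCCCCCCNC(=O)[C@H]1CSC(CCCCCCCCCCCC)N1` carries a dodecyl chain on its core. Among the compounds with values here, in a functional assay on PPC-1 cells (Homo sapiens) for antiproliferative activity, read by sulforhodamine B assay (on this read-out higher numbers stand for weaker inhibition and lower numbers for stronger inhibition), compound 1 gives 13000 nM, the second highest of the three numbers known here. Compound 2 `CCCCCCCCCCCCCCCCCCNC(=O)[C@H]1CSC(Cc2ccccc2)N1` gives 4000 nM, and compound 3 `CCCCCCCCCCCCCCCCCCNC(=O)[C@H]1CSC(c2ccc([N+](=O)[O-])cc2)N1` gives 15300 nM. The step of a 3.3-fold lower number from compound 1 to compound 2 (0.51 log units; beyond the scatter), whereas the step of a 1.2-fold higher number from compound 1 to compound 3 (0.07 log units; within the scatter). Between the two aromatic compounds, the step of a 3.8-fold higher number from compound 2 to compound 3 (0.58 log units; beyond the scatter).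

Compound 4 `CCCCCCCCCCCCCCCCCCNC(=O)[C@H]1CSC(c2ccc(C#N)cc2)N1` has not yet been measured. It differs from compound 1 in one place: 4-cyanophenyl in place of dodecyl on a saturated ring carbon. The measured step that bears most directly on this change is a 1.2-fold higher number from compound 1 to compound 3 (0.07 log units; within the scatter), where an aromatic group also replaced the dodecyl chain on the same saturated ring carbon and the number stayed within the scatter. The step of a 3.3-fold lower number from compound 1 to compound 2 (0.51 log units; beyond the scatter) concerns a chain carbon rather than the ring carbon and is less informative. The expectation is therefore a step of little size, likely within the scatter. Compound 4 is expected to give 13000 nM, between 6000 nM and 30000 nM. This estimate means an expected step of no change at the digits printed from compound 1 to compound 4 (within the scatter).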

Compound 4, half-maximal inhibitory concentration: 5000 nM
Compound 4: the middle estimate sits 2.6-fold (0.41 log units) above what was measured, and the stated range ends above it.
By their numbers in this assay, from the lowest: compounds 2 and 4 (each within the scatter of the next); then compounds 1 and 3 (each within the scatter of the next).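

Compound 3 had suggested that an aromatic group in place of dodecyl on this saturated ring carbon changes little, but the 4-cyanophenyl group gives a 2.6-fold lower number from compound 1 to compound 4 (0.41 log units; beyond the scatter) in this assay. The outcome of the swap therefore depends on what the aromatic ring carries: cyano in place of nitro on an aromatic carbon alone gives a 3.1-fold lower number from compound 3 to compound 4 (0.49 log units; beyond the scatter) and brings compound 4 level with the benzyl compound, with a 1.3-fold higher number from compound 2 to compound 4 (0.10 log units; within the scatter) as the step between them. No measurement here accounts for the difference between the nitrile and the nitro group.

The compounds shown leave open how an amine or a carboxylic acid would fare in place of cyano on the aromatic ring. They also leave open whether a chloro group there would match cyano or nitro.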